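The source may hold more compounds than are shown below. What is called first, only, known or untested is meant among the compounds shown, and "the series" means these compounds.

Working notes on the series in an assay on membranes from lung for binding affinity to cysteinyl leukotriene receptor 1 (Cavia porcellus); a lower number here means a stronger inhibitor, a higher number a weaker inhibitor. Within the data shown here, the shared core is carried by compound 1 `O[C@@H]1c2cc(OCc3ccc4ccccc4n3)ccc2OC[C@@H]1Cc1cccnc1`, which gives 1640 nM and sits second highest of the three numbers so far; its nearest neighbour is compound 3 `Cc1nc(COc2ccc3c(c2)[C@@H](O)[C@@H](Cc2cccnc2)CO3)ccc1Br`, which gives 1560 nM, and the furthest is compound 2 `O[C@@H]1c2cc(OCc3cccc(Cl)n3)ccc2OC[C@@H]1Cc1cccnc1`, which gives 23400 nM. The step to compound 2 is a 14-fold higher number from compound 1 to compound 2 (1.15 log units; beyond the scatter), while the step to compound 3 is a 1.1-fold lower number from compound 1 to compound 3 (0.02 log units; within the scatter), so the two pyridinyl replacements go in opposite directions, with a 15-fold lower number from compound 2 to compound 3 (1.18 log units; beyond the scatter) between them.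

Compound 4 `O[C@@H]1c2cc(OCc3cccc(F)n3)ccc2OC[C@@H]1Cc1cccnc1` has not yet been measured in this assay. Its change from compound 1 is 6-fluoropyridin-2-yl in place of quinolin-2-yl on a saturated chain carbon bound to an oxygen on an aromatic ring. Of the measured steps, a 14-fold higher number from compound 1 to compound 2 (1.15 log units; beyond the scatter) bears most directly, since compound 2 also carries a single halogen on the pyridinyl in the same place; compound 3 shows that a further methyl and a different halogen can undo that loss, but compound 4 carries neither. A large step upward, near the size seen for compound 2, is therefore expected for compound 4, an 11-fold higher number from compound 1 to compound 4 (1.04 log units; beyond the scatter). Compound 4 is estimated at 18000 nM, in a range from 5000 nM to 60000 nM.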

Compound 4, inhibition constant in the cysteinyl leukotriene receptor 1 assay: > 100000 nM
Compound 4 ended at the assay's limit (the forecaster's own chance of this, stated with the estimate: 5%); middle value at least 5.5-fold (0.74 log units) away from the limit.
By their numbers in the cysteinyl leukotriene receptor 1 assay, from the lowest: compounds 3 and 1 (each within the scatter of the next); then compound 2. At a limit, above all of these: compound 4.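

In the cysteinyl leukotriene receptor 1 assay, compound 4 stands at a limit of the assay, not at a number: the limit of > 100000 nM in the cysteinyl leukotriene receptor 1 assay, at which 1 of the 4 values shown sits. Even so, the steps can be read as bounds: an at least 60-fold higher number from compound 1 to compound 4 (1.78 log units; beyond the scatter) and an at least 64-fold higher number from compound 3 to compound 4 (1.80 log units; beyond the scatter), while the single swap of fluoro in place of chloro on an aromatic carbon gives an at least 4.2-fold higher number from compound 2 to compound 4 (0.63 log units; beyond the scatter), so the identity of the halogen matters at this position, not only the departure of quinolin-2-yl. In a physicochemical assay for acid dissociation, compound 1 gives 4.81 and compound 4 gives -0.44, so the change from quinolin-2-yl to 6-fluoropyridin-2-yl also comes with a large shift: the measured acid dissociation constant of compound 1, 4.81, and of compound 4, -0.44, a number 5.25 log units lower (beyond the scatter).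

As far as these compounds go, whether that shift is tied to the loss of binding remains open, as compound 1 and compound 4 differ in the whole group. A 6-aminopyridin-2-yl or 6-methoxypyridin-2-yl in the same place would extend the comparison beyond halogens.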